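Methoxy in place of methyl on an aromatic carbon

The compounds below may be only part of what the source reports. "The series", "measured", "known", "first", "only" and "open" are said of these compounds alone.

Compound 1 `C=C1C(=O)[C@@]23C(=O)OC[C@]4(C(=O)CCC(C)(C)[C@H]4C=O)[C@@H]2CC[C@@H]1[C@H]3OC(=O)c1ccccc1`: 1850 nM
Compound 2 `C=C1C(=O)[C@@]23C(=O)OC[C@]4(C(=O)CCC(C)(C)[C@H]4C=O)[C@@H]2CC[C@@H]1[C@H]3OC(=O)c1ccc(C)cc1`: 1540 nM

In a functional assay on Bel-7402 cells (Homo sapiens) for cytotoxicity, read by MTT assay, with a stated time of 72 h (a higher number here means a weaker inhibitor, a lower number a stronger inhibitor), compound 2 gives 1540 nM. Only compound 1 has been measured alongside it, and the two values lie within the scatter of each other, so the numbers do not separate them. Going by the values given here, one measured step bears on the next change, methyl in place of hydrogen on an aromatic carbon: a 1.2-fold lower number from compound 1 to compound 2 (0.08 log units; within the scatter).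

Compound 3 `C=C1C(=O)[C@@]23C(=O)OC[C@]4(C(=O)CCC(C)(C)[C@H]4C=O)[C@@H]2CC[C@@H]1[C@H]3OC(=O)c1ccc(OC)cc1` differs from compound 2 at that kind of site, with methoxy in place of methyl on an aromatic carbon, para to a large group: methoxy in place of methyl on an aromatic carbon. The rest of the structure stays the same. Among the compounds with values here, no measured compound yet carries methoxy, so the evidence for this change is thin and indirect. On the strength of a 1.2-fold lower number from compound 1 to compound 2 (0.08 log units; within the scatter), no step beyond the scatter is expected in this assay, and no direction is favoured. The estimated step is a 1.0-fold lower number from compound 2 to compound 3 (0.01 log units; within the scatter). For compound 3 the expected value is 1500 nM, with an estimated range of 800 nM to 2800 nM.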

Compound 3, half-maximal inhibitory concentration: 2800 nM
Compound 3: middle estimate off by 1.9-fold (0.27 log units), on the low side; the measured number falls inside the stated range.
By their numbers in this assay, from the lowest: compounds 2, 1 and 3 (each within the scatter of the next).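

With methoxy now on the aromatic carbon para to a large group, this assay gives a direct reading of this change (the step is a 1.8-fold higher number from compound 2 to compound 3 (0.26 log units; within the scatter)), and the same site can also be read against the unsubstituted 
phenyl of compound 1 (the step is a 1.5-fold higher number from compound 1 to compound 3 (0.18 log units; within the scatter)). Neither step lies beyond the scatter, so the numbers do not separate hydrogen, methyl and methoxy at this site, and the exchange of 4-methylphenyl for 4-methoxyphenyl shows no measurable effect on the read-out across these three compounds. Nothing measured here offers an account of the values of these compounds or of the steps between them.

The compounds shown leave open whether any group at this site can produce a step beyond the scatter, for instance an amine, a carboxylic acid, a chlorine atom or a longer chain such as butoxy. They also leave open whether methyl or methoxy would read the same on another carbon of the aromatic ring, since all three compounds vary only at this one site while the shared core stays the same.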